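The source may report more compounds than this note shows. Statements on the series, on what has been measured and on what is new or still open speak of the compounds shown alone.

Working notes on the acylguanidine series in a functional assay for inhibition of sodium/hydrogen exchanger (Oryctolagus cuniculus); on this read-out lower numbers stand for stronger inhibition and higher numbers for weaker inhibition. Three compounds carry numbers. Compound 1 `CCCc1cc(C)c(C(=O)N=C(N)N)cc1S(C)(=O)=O` gives 5.7 nM; compound 2 `Cc1cc(C2CCC2)c(S(C)(=O)=O)cc1C(=O)N=C(N)N` gives 8.2 nM; compound 3 `Cc1c(C(=O)N=C(N)N)cc(S(C)(=O)=O)c(C)c1C` gives 55 nM. Among the compounds with values here, the single one-point step recorded so far, a 1.4-fold higher number from compound 1 to compound 2 (0.16 log units; within the scatter), is the exchange of propyl for cyclobutyl on the same aromatic carbon. Compound 2 therefore stands second highest of the three numbers, with compound 1 nearest at a gap within the scatter and compound 3 furthest at a gap beyond it; compound 3 differs from compound 2 in more than one place, so its two values are read only as such.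

The next compound, compound 4 `CCSc1cc(C)c(C(=O)N=C(N)N)cc1S(C)(=O)=O`, departs from compound 2 by ethylsulfanyl in place of cyclobutyl on an aromatic carbon. Within the data shown here, the only measured step that bears on this position, a 1.4-fold higher number from compound 1 to compound 2 (0.16 log units; within the scatter), was within the scatter, which suggests that this aromatic carbon tolerates a change of substituent. Among the measured compounds shown here, the entering group brings a sulfur atom and one hydrogen-bond acceptor, for which no step exists; an expectation beyond the scatter cannot be built from the data. Compound 4 is therefore estimated at 8 nM, range 3 nM to 22 nM, meaning an expected step of a 1.0-fold lower number from compound 2 to compound 4 (0.01 log units; within the scatter), essentially no step beyond the scatter.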

Compound 4, half-maximal inhibitory concentration: 5.9 nM
Estimate against measurement, compound 4: 1.4-fold (0.13 log units) above; the measured number falls inside the stated range.
By their numbers in this assay, from the lowest: compounds 1, 4 and 2 (each within the scatter of the next); then compound 3.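

In this assay, the readings a 1.4-fold lower number from compound 2 to compound 4 (0.14 log units; within the scatter) and a 1.0-fold higher number from compound 1 to compound 4 (0.01 log units; within the scatter) both stay within the scatter, so no difference can be drawn among propyl, cyclobutyl and ethylsulfanyl on this aromatic carbon, ortho to a methylsulfonyl group. The earlier compounds shown here showed this only for two carbon groups; the series now adds a group with a sulfur atom and a hydrogen-bond acceptor, and at compound 2 the change also removes the four-membered ring, yet neither change moves the number beyond the scatter. Nothing available explains this flat reading, which therefore stands only as a description of the numbers.

Still open, from the compounds shown here alone, is whether the flat reading holds for groups of a different kind on this carbon, such as an amine, a carboxylic acid or a longer chain. Compound 3 differs from the other compounds in more than one place, so it gives no separate reading on this carbon, and the methyl and methylsulfonyl groups stay unvaried throughout the one-place steps shown here.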